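This account rests on a few compounds, and the source may have more. Where it says the series, first, only, none or still open, it means among the compounds named here.

Measured in an ADME assay on HEp-2 cells (Homo sapiens) for cytotoxicity, read by MTT assay, with a stated time of 72 h; a higher number here means a weaker inhibitor, a lower number a stronger inhibitor:
compound 1 `COc1cc(C2=C(c3cc(C)c(OC)c(C)c3)C(O)CC2=O)cc(OC)c1OC` — a limit only, > 100 ug/mL
compound 2 `COc1ccc(C2=C(c3cc(OC)c(OC)c(OC)c3)C(=O)C(OC(C)=O)C2)cc1O` — a limit only, > 100 ug/mL
compound 3 `C=CCOc1cc(C2=C(c3cc(OC)c(OC)c(OC)c3)C(=O)C(O)C2)ccc1OC` — a limit only, > 100 ug/mL

None of the three readings is a number; each is a limit of this assay, so the measured set gives no ranking of any kind. Compound 1 stands at the limit of > 100 ug/mL in this assay, at which 3 of the 3 values shown sit, and the two further readings sit at the same place, so no order between compound 1 and either of the other two can be drawn. Among the measured compounds shown here, no pair of measured compounds differs in a single place, so no step is available within the set.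

Compound 4 `COc1cc(C2=C(c3cc(C)c(OC)c(C)c3)C(OC(C)=O)CC2=O)cc(OC)c1OC` is the one still to be tested in this assay. It differs from compound 1 by acetyl in place of hydrogen on an oxygen on a saturated carbon; cut one bond further out, the change reads hydroxy to acetoxy. For the measured compounds named here, because every measured reading sits at the limit of > 100 ug/mL in this assay, at which 3 of the 3 values shown sit, no step of any direction beyond the scatter is expected for this change, and a limit rather than a number is the most likely outcome. The expected step is a step that the limit leaves unreadable from compound 1 to compound 4. Compound 4 is estimated at 150 ug/mL in this assay, with a range from 60 ug/mL to 400 ug/mL.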

Compound 4, half-maximal inhibitory concentration: > 100 ug/mL
Compound 4: no number, only a limit; the forecaster's own chance of this, stated with the estimate: 85%; the middle value does not contradict the limit.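

No step can be read from compound 1 to compound 4 in this assay, as both readings are limits and not numbers: the limit of > 100 ug/mL in this assay, at which 4 of the 4 values shown sit.

The compounds shown leave open how the change from hydroxy to acetoxy affects the reading in this assay, and at what concentration, if any, each compound reaches half-maximal inhibition.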